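Fluoro for Methoxycarbonyl on the Core of Compound 1

The source may hold more compounds than are shown below. What is called first, only, known or untested is meant among the compounds shown, and "the series" means these compounds.

compound 1, `COC(=O)c1ccc(Nc2[nH]cnc3ncnc2-3)cc1`: in an assay on isolated protein for inhibition of MAP kinase-interacting serine/threonine-protein kinase 1 (Homo sapiens) (on this read-out higher numbers stand for weaker inhibition and lower numbers for stronger inhibition), compound 1 gives 850 nM
compound 2, `c1ccc2cc(Nc3ncnc4[nH]ncc34)ccc2c1`: in this assay compound 2 gives 1350 nM
compound 3, `CNc1ccc2ncc(-c3ccc(F)cc3)n2n1`: in this assay compound 3 gives 4050 nM

Compound 1 has the lowest of the three numbers. Compound 2 lies within the usual scatter of it, so no order between those two can be read; only compound 3 stands beyond the scatter, with the higher number of the set. The three compounds share no single-point changes with each other, so nothing here shows how one substituent swap on compound 1 moves the read-out.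

Compound 4, `Fc1ccc(Nc2[nH]cnc3ncnc2-3)cc1`, differs from compound 1 in one place: fluoro in place of methoxycarbonyl on an aromatic carbon. The methoxycarbonyl group that leaves is the only substituent on that ring in compound 1, and the fluoro that enters is much smaller by the count given. Within the data shown here, with no comparable step among the measured compounds, the size of the change cannot be anchored; a modest move toward weaker inhibition, around the edge of the scatter, is the expectation. Compound 4 is therefore estimated at 1600 nM, in a range from 500 nM to 5000 nM, which would mean an expected step of a 1.9-fold higher number from compound 1 to compound 4 (0.27 log units; within the scatter).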

Compound 4, half-maximal inhibitory concentration: 1030 nM
Compound 4: middle estimate off by 1.6-fold (0.19 log units), on the high side; the range from low to high includes it.
By their numbers in this assay, from the lowest: compounds 1, 4 and 2 (each within the scatter of the next); then compound 3.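

Among these compounds, the exchange of methoxycarbonyl for fluoro, para to a large group on the ring, is the first single-point change available on compound 1, and it gives a 1.2-fold higher number from compound 1 to compound 4 (0.08 log units; within the scatter) in this assay on this read-out. The group that leaves has 4 heavy atoms and 2 hydrogen-bond acceptors, while the one that enters has 1 heavy atom and no acceptors, yet the two compounds cannot be told apart. Methoxycarbonyl is therefore not shown to be needed at this position for a number in this range, and no measurement given here offers an explanation for the result.

As far as these compounds go, whether an amine, a carboxylic acid or a longer chain at this position would move the number beyond the scatter remains open. Among the compounds shown here, with only one step at this position, no trend across substituents can be drawn.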